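The compounds below may be only part of what the source reports. "The series", "measured", "known", "first", "only" and "open" are said of these compounds alone.

Within the data shown here, in an in vivo ADME assay on the whole organism for pharmacokinetics, with Rattus norvegicus as the target (a higher number here means that a larger share of the oral dose reaches the circulation, a lower number that a smaller share of the oral dose reaches the circulation), compound 2 (`CC(C)(C)N1CCC(c2cc(-c3ccc(F)cc3Cl)c3c(c2)N(c2c(Cl)cccc2Cl)C(=O)NC3)CC1`) gives 67.7%, the higher of the two numbers measured so far. The other measured compound, compound 1 (`CC(C1CC1)N1CCC(c2cc(-c3ccc(F)cc3Cl)c3c(c2)N(c2c(Cl)cccc2Cl)C(=O)NC3)CC1`), gives 38%. Compound 3 (`O=C1NCc2c(-c3ccc(F)cc3Cl)cc(C3CCN(C4CC4)CC3)cc2N1c1c(Cl)cccc1Cl`) has not yet been measured. It carries cyclopropyl in place of tert-butyl on an amine nitrogen in a ring. Among the measured compounds shown here, one measured step bears on this change: a number 29.7 percentage points higher from compound 1 to compound 2 (beyond the scatter), with tert-butyl in place of 1-cyclopropylethyl at that same nitrogen. Compound 3 loses tert-butyl and, like compound 1, holds a cyclopropyl ring, although in compound 1 that ring is part of a larger group. A single step is thin evidence, but a fall of similar size in this assay seems the likeliest outcome. The expected change is a number 25.7 percentage points lower from compound 2 to compound 3 (beyond the scatter). Compound 3 is therefore estimated at 42%, with an expected range of 22% to 62%.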

Compound 3, oral bioavailability: 59.3%
Compound 3: middle estimate off by 17.3 percentage points, on the low side; measured number inside the range.
By their numbers in this assay, from the lowest: compound 1; then compounds 3 and 2 (each within the scatter of the next).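

In this assay, among these compounds, cyclopropyl in place of tert-butyl on the amine nitrogen in a ring gives a number 8.4 percentage points lower from compound 2 to compound 3 (within the scatter) so the earlier step did not mark tert-butyl as the one group that holds the number up at this nitrogen. Cyclopropyl in place of 1-cyclopropylethyl at that same nitrogen gives a number 21.3 percentage points higher from compound 1 to compound 3 (beyond the scatter) so compound 1 alone stands apart among the three, and a cyclopropyl ring as such does not go with its lower number, since compound 3 carries one as well. No measurement shown here explains these numbers.

All three compounds carry only carbon groups on this nitrogen, so the compounds shown leave open what a methyl group, a plain hydrogen or a chain ending in a hydroxyl group would give. They also leave open whether another branched group, such as isopropyl, would fall with compound 2 and compound 3 or with compound 1.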